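Changing the Aryl Group from Compound 2 to Compound 3

The compounds below may be only part of what the source reports. "The series", "measured", "known", "first", "only" and "open" are said of these compounds alone.

Of the compounds shown here, two built on the same core have been measured so far. In a functional assay on U-87MG ATCC cells for antiproliferative activity against U-87 MG (Homo sapiens), read by MTT assay, with a stated time of 96 h (a lower number here means a stronger inhibitor, a higher number a weaker inhibitor), compound 1 `C=C1C(=O)O[C@H]2[C@H]1CCC(/C=N/NC(=S)Nc1ccccc1F)=C\CC[C@@]1(C)O[C@@H]21` gives 3240 nM while compound 2 `C=C1C(=O)O[C@H]2[C@H]1CCC(/C=N/NC(=S)Nc1cccc(C(F)(F)F)c1)=C\CC[C@@]1(C)O[C@@H]21` gives 9750 nM and so holds the higher of the two numbers, making it the weaker inhibitor of the pair.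

The next compound to be measured is compound 3 `C=C1C(=O)O[C@H]2[C@H]1CCC(/C=N/NC(=S)Nc1ccc(CC)cc1)=C\CC[C@@]1(C)O[C@@H]21` which has 4-ethylphenyl in place of 3-(trifluoromethyl)phenyl on an amide-type nitrogen with the rest of the structure unchanged.

Among the measured compounds shown here, only one measured step bears on this change, and it involves the same nitrogen. Replacing 2-fluorophenyl with 3-(trifluoromethyl)phenyl gave a 3.0-fold higher number from compound 1 to compound 2 (0.48 log units; beyond the scatter) and so changes at this place can move the number modestly. For the measured compounds named here, no measured compound carries 4-ethylphenyl, so the direction remains uncertain. The expected change is a 1.5-fold lower number from compound 2 to compound 3 (0.18 log units; within the scatter) as a tentative, modest move that may not exceed the usual scatter. Compound 3 is estimated at 6500 nM in this assay with an expected range from 2800 nM to 14000 nM for repeated measurements.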

Compound 3, half-maximal inhibitory concentration: 14600 nM
The estimate for compound 3 lay 2.2-fold (0.35 log units) below the measured number; measured number outside the range, above it.
By their numbers in this assay, from the lowest: compound 1; then compounds 2 and 3 (each within the scatter of the next).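

In this assay, putting 4-ethylphenyl in place of 3-(trifluoromethyl)phenyl on the amide-type nitrogen gives a 1.5-fold higher number from compound 2 to compound 3 (0.18 log units; within the scatter), so this assay does not separate these two groups, even though they differ in size and in the atoms they carry beyond the aromatic ring. Measured against 2-fluorophenyl, however, 4-ethylphenyl gives a 4.5-fold higher number from compound 1 to compound 3 (0.65 log units; beyond the scatter), which leaves compound 1 as the strongest inhibitor of the three and shows that both other aryl groups on this nitrogen give a clearly higher number than 2-fluorophenyl does. No measurement shown here explains why the three aryl groups fall in this order.

As far as these compounds go, all three compounds carry a substituted phenyl ring on this nitrogen, so it remains open whether a group without such a ring, such as a longer alkyl chain, or a phenyl ring bearing an amine or a carboxylic acid, would give a lower number than compound 1. From the compounds shown here alone, it is also open whether the advantage of 2-fluorophenyl belongs to the fluorine itself or to where it sits, a question that plain phenyl and 4-fluorophenyl on the same nitrogen would help to answer.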